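Inverting one chain stereocentre: outlook for compound 4

The source may report more compounds than this note shows. Statements on the series, on what has been measured and on what is new or still open speak of the compounds shown alone.

Measured so far in a functional assay on the whole organism (stomach) with Rattus norvegicus as the target; a higher number here means that more compound is needed for the effect, a lower number that less compound is needed
- compound 1 `CCCC[C@](C)(OC)[C@@H](O)/C=C/C1[C@H](O)CC(=O)[C@@H]1C/C=C\CCCC(=O)OC` gives 1.5 mg/kg
- compound 2 `CCCC[C@](C)(OC)[C@H](O)/C=C/C1[C@H](O)C[C@H](O)[C@@H]1C/C=C\CCCC(=O)OC` gives > 2 mg/kg (a limit)
- compound 3 `CCCC[C@](C)(OC)[C@H](O)/C=C/C1[C@H](O)CC(=O)[C@@H]1C/C=C\CCCC(=O)OC` gives 0.5 mg/kg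

Compound 2 is known only by a limit (> 2 mg/kg), so no number exists for it. Compound 4 `CCCC[C@](C)(OC)[C@@H](O)/C=C/C1[C@H](O)C[C@H](O)[C@@H]1C/C=C\CCCC(=O)OC` has not yet been measured in this assay and keeps the whole structure of compound 2 except for one centre (the two compounds have the same atoms and bonds; at least one stereo element is drawn with a configuration in one of them and without one in the other: 1 of 8 stereo elements differ; a stereocentre at a saturated chain carbon is drawn R in compound 2 and S in compound 4). Among the measured compounds shown here, the one measured step that bears on this is at the same chain centre, with the configuration changing the opposite way (a 3.0-fold lower number from compound 1 to compound 3 (0.48 log units; beyond the scatter)). Read in reverse, that modest step points to a higher number for compound 4 than for compound 2. It is a single step, however, from a pair that carries a carbonyl where compound 2 and compound 4 carry a hydroxyl. The expected change is a step that the limit leaves unreadable from compound 2 to compound 4, of similar modest size and upward. Compound 4 is estimated at 6 mg/kg, with an expected range from 2 mg/kg to 20 mg/kg. A result reported only as a limit is also likely.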

Compound 4, dose for 50% inhibition: > 4 mg/kg
Compound 4: a limit, no number (the forecaster's own chance of this, stated with the estimate: 75%); the middle value does not contradict the limit.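

Among the compounds shown here, compound 2 and compound 4 are both known only as limits in this assay, so no step between them can be read. Still open, going by these compounds, is whether the chain stereocentre matters in this hydroxyl pair as it does in the carbonyl pair, which shows a 3.0-fold lower number from compound 1 to compound 3 (0.48 log units; beyond the scatter).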